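A few compounds are considered here, and "the series" means these few. Any claim that something is new, unique, unknown or untested is made for them only; others in the source may bear on it.

Measured so far:
compound 1 `CCc1cc(C(C)=O)c(O)cc1OCCCCCC(C)(C)c1nnnn1C` — 99%
compound 2 `C=CCc1cc(C(C)=O)c(O)cc1OCCCCC` — 60%

In an assay on isolated protein for inhibition of leukotriene B4 receptor 1 (Homo sapiens), tested at 10 uM (on this read-out lower numbers stand for less inhibition and higher numbers for more inhibition at the one concentration tested (going by the name of the read-out)), compound 1 gives 99% and compound 2 gives 60%. Compound 2 thus stands lowest of the two numbers; its nearest neighbour is compound 1, and the gap between them lies beyond the usual scatter of repeated measurements. Among the compounds with values here, no single-point step between measured compounds is available, so the difference between these two cannot be tied to one change.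

Compound 3 `C=CCc1cc(C(C)=O)c(O)cc1OCCCCCC(=O)N(C)C` remains to be measured in this assay. It differs from compound 2 in one place: dimethylcarbamoyl in place of hydrogen on a saturated chain carbon, five bonds along the chain from an oxygen on an aromatic ring. Within the data shown here, with no comparable measured step on hand, the expectation rests on compound 2 alone, which gives 60%, and on the wider series in which compound 1, carrying a longer substituted chain, gives 99%. A moderate increase in inhibition is expected rather than none, and compound 3 is estimated at 75% (range 50% to 95%). The step this estimate means is a number 15 percentage points higher from compound 2 to compound 3 (beyond the scatter).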

Compound 3, a percentage reported as inhibition, at one concentration (the size of the read-out at that concentration, not a potency): 92%
The estimate for compound 3 lay 17 percentage points below the measured number, and the stated range covers the measured number.
By their numbers in this assay, from the lowest: compound 2; then compounds 3 and 1 (each within the scatter of the next).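

On the saturated chain carbon five bonds along the chain from an oxygen on an aromatic ring, dimethylcarbamoyl in place of hydrogen gives a number 32 percentage points higher from compound 2 to compound 3 (beyond the scatter) in this assay, so this position accepts a substituent and the inhibition rises with it. Within the data shown here, this is the first difference that can be tied to a single change, which the earlier pair of compounds could not provide. No supporting measurement is at hand to account for the rise.

The compounds shown do not separate the contribution of the dimethylcarbamoyl group from that of the added chain length, which a longer unsubstituted chain at this position would address. As far as these compounds go, whether the same position also accepts a carboxylic acid or an amine remains open.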